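Chlorination of a purine core and cytotoxicity in prostate cancer cells

This account rests on a few compounds, and the source may have more. Where it says the series, first, only, none or still open, it means among the compounds named here.

Compound 1, `ClCc1ccccc1Cn1cnc2c(Cl)nc(Cl)nc21`, gives 6310 nM.
Compound 2, `ClCc1ccccc1Cn1cnc2c(Cl)ncnc21`, reaches only the limit of the test, > 100000 nM.
Compound 3, `ClCc1cccc(Cn2cnc3c(Cl)ncnc32)c1`, gives 51300 nM.

All three were tested in a functional assay on DU-145 cells (Homo sapiens) for cytotoxicity, read by sulforhodamine B assay, with a stated time of 48 h; on this read-out lower numbers stand for higher toxicity in this test and higher numbers for lower toxicity in this test. Compound 2 sits at the limit of > 100000 nM in this assay, at which 1 of the 3 values shown sits, so its value is a limit and not a number. From compound 2 to compound 1 the change is chloro in place of hydrogen on an aromatic carbon; it brought an at least 15-fold lower number from compound 2 to compound 1 (1.19 log units; beyond the scatter). The size of that step is a bound, since compound 2 stands at the limit of > 100000 nM in this assay, at which 1 of the 3 values shown sits.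

Compound 3 carries the same atoms as compound 2, joined differently; how the two cores differ is not broken down here. In this assay compound 3 stands above compound 1, and the gap between them lies beyond the scatter.

Compound 4, `ClCc1cccc(Cn2cnc3c(Cl)nc(Cl)nc32)c1`, has not yet been measured in this assay. It differs from compound 3 by chloro in place of hydrogen on an aromatic carbon, the same change that separates compound 2 from compound 1, at a place described in the same words. Beside the measured step of an at least 15-fold lower number from compound 2 to compound 1 (1.19 log units; beyond the scatter), a step of a 13-fold lower number from compound 3 to compound 4 (1.11 log units; beyond the scatter) is expected from compound 3 to compound 4, resting on that earlier step and on the value of compound 3, 51300 nM. Compound 4 is therefore estimated to give 4000 nM in this assay, within a range from 1500 nM to 15000 nM.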

Compound 4, concentration lethal to 50% of the cells: 5620 nM
Beside the measured number, compound 4's estimate is 1.4-fold (0.15 log units) below it; low and high end bracket the measured number.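

In this assay, chloro in place of hydrogen on the aromatic carbon between two ring nitrogen atoms brought a 9.1-fold lower number from compound 3 to compound 4 (0.96 log units; beyond the scatter), so on this second core the change again lowered the number by more than the scatter. The comparison with the first core has a weak point, as compound 2 stands at a limit of the test and not at a number: the limit of > 100000 nM in this assay, at which 1 of the 4 values shown sits. The two pairs show the same direction on two cores, but they make no general rule and do not settle whether the step has the same size on both: the same change on two cores in this assay, an at least 15-fold lower number (1.19 log units; beyond the scatter) from compound 2 to compound 1 and a 9.1-fold lower number (0.96 log units; beyond the scatter) from compound 3 to compound 4; the limit leaves it open whether they differ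

The compounds shown carry only hydrogen or chloro on that aromatic carbon, so it stays open whether bromo, a methoxy group or an amine there would move the number in the same way. Also open, as far as these compounds go, is what would follow if the chloromethyl group present in all four compounds gave way to a hydroxymethyl group or a longer chain, or if the chloro shared by all four were replaced by an amine.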